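Trifluoromethoxy for trifluoromethyl on two benzimidazole cores

The source may report more compounds than this note shows. Statements on the series, on what has been measured and on what is new or still open speak of the compounds shown alone.

Compound 1 `Oc1cccc2[nH]c(-c3ccc(-c4ccc(-c5ccc(C(F)(F)F)cc5)cc4)cc3)nc12`, 4320 nM; compound 2 `Oc1cccc2[nH]c(-c3ccc(-c4ccc(-c5ccc(OC(F)(F)F)cc5)cc4)cc3)nc12`, 3310 nM; compound 3 `Cc1ccc2[nH]c(-c3ccc(-c4ccc(-c5ccc(C(F)(F)F)cc5)cc4)cc3)nc2c1`, 41200 nM.

Of the compounds shown here, three have been measured in a functional assay on KB cells (Homo sapiens) for inhibition, read by sulforhodamine B assay; a lower number here means a stronger inhibitor of growth, a higher number a weaker inhibitor of growth. Compound 1 and compound 2 differ by trifluoromethoxy in place of trifluoromethyl on an aromatic carbon, a change that gave a 1.3-fold lower number from compound 1 to compound 2 (0.12 log units; within the scatter). Compound 3 carries a different core: 5-methyl-1H-benzimidazol-2-yl in place of 4-hydroxy-1H-benzimidazol-2-yl on an aromatic carbon, and this made a 9.5-fold higher number from compound 1 to compound 3 (0.98 log units; beyond the scatter). Compound 4 `Cc1ccc2[nH]c(-c3ccc(-c4ccc(-c5ccc(OC(F)(F)F)cc5)cc4)cc3)nc2c1` is not yet measured; it stands to compound 3 as compound 2 stands to compound 1, the change being (trifluoromethoxy in place of trifluoromethyl on an aromatic carbon), at the same place and so the same change. Because the earlier step was a 1.3-fold lower number from compound 1 to compound 2 (0.12 log units; within the scatter), compound 4 is expected to give a number close to that of compound 3, estimated as a 1.2-fold lower number from compound 3 to compound 4 (0.10 log units; within the scatter) in this assay. The estimate for compound 4 in this assay is 33000 nM, between 15000 nM and 75000 nM.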

Compound 4, concentration for 50% growth inhibition: 41200 nM
The estimate for compound 4 lay 1.2-fold (0.10 log units) below the measured number, within the range that was stated.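

In this assay, trifluoromethoxy in place of trifluoromethyl gave no change at the digits printed from compound 3 to compound 4 (within the scatter), and this step carried from the core of compound 1 to the core of compound 3 without a difference that can be told apart: the same change on two cores in this assay, a 1.3-fold lower number (0.12 log units; within the scatter) from compound 1 to compound 2 and no change at the digits printed (within the scatter) from compound 3 to compound 4, 1.3-fold (0.12 log units) apart, within the scatter of two such steps The change of core, made with trifluoromethoxy in place, gave a 12-fold higher number from compound 2 to compound 4 (1.10 log units; beyond the scatter), and it too matched its earlier counterpart: the same change on two cores in this assay, a 9.5-fold higher number (0.98 log units; beyond the scatter) from compound 1 to compound 3 and a 12-fold higher number (1.10 log units; beyond the scatter) from compound 2 to compound 4, 1.3-fold (0.12 log units) apart, within the scatter of two such steps Across these four compounds the two changes therefore behave independently, but this does not show that the swap itself alters growth inhibition on either core, and two cores cannot establish that it would transfer to a third.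

The compounds shown leave open whether this independence would hold with an amine or a nitrile in place of trifluoromethyl. They also leave open how a carboxylic acid or a methoxy group in place of the hydroxy or methyl group on the core would behave.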